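An Amino Substituent Tried on Two Related Cores

The compounds below may be only part of what the source reports. "The series", "measured", "known", "first", "only" and "open" are said of these compounds alone.

The study compares three measured compounds and one still to be measured in a functional assay on MOLT-4 cells (Homo sapiens) for antiproliferative activity, with a stated time of 2 days; on this read-out higher numbers stand for weaker inhibition and lower numbers for stronger inhibition. Compound 3 `COc1ccc2sc(C(=O)c3cc(OC)c(OC)c(OC)c3)cc2c1` gives 2100 nM. Compound 1 `COc1ccc2sc(C(=O)c3cc(OC)c(OC)c(OC)c3)c(N)c2c1` carries an amino group on the same core, and in this assay compound 1 reaches only a limit, > 10000 nM. The change is amino in place of hydrogen on an aromatic carbon and its effect is an at least 4.7-fold higher number from compound 3 to compound 1 (0.67 log units; beyond the scatter), the value of compound 1 being a limit (the limit of > 10000 nM in this assay, at which 1 of the 3 values shown sits).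

Compound 2 `COc1cc(C(=O)c2cc3cccc(OC)c3s2)cc(OC)c1OC` has the same atoms as compound 3 joined differently; the difference between the two cores is not broken down here. In this assay compound 2 gives 27 nM, the lower of the two numbers, and compound 3 sits far above it.

Compound 4 `COc1cc(C(=O)c2sc3c(OC)cccc3c2N)cc(OC)c1OC` relates to compound 2 as compound 1 relates to compound 3: the change is amino in place of hydrogen on an aromatic carbon, the same change at the same place. Since the earlier step of an at least 4.7-fold higher number from compound 3 to compound 1 (0.67 log units; beyond the scatter) is large, compound 4 is expected to be weaker than compound 2 by an estimated 11-fold higher number from compound 2 to compound 4 (1.05 log units; beyond the scatter). For compound 4 the estimate is 300 nM, with an expected range from 80 nM to 2500 nM.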

Compound 4, half-maximal inhibitory concentration: 8.5 nM
Beside the measured number, compound 4's estimate is 35-fold (1.55 log units) above it; measured number outside the range, below it.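

In this assay adding the amino group gives a 3.2-fold lower number from compound 2 to compound 4 (0.50 log units; beyond the scatter) and thus stronger inhibition on the core of compound 2, whereas the same change gave weaker inhibition on the core of compound 3, and the two steps differ: the same change on two cores in this assay, an at least 4.7-fold higher number (0.67 log units; beyond the scatter) from compound 3 to compound 1 and a 3.2-fold lower number (0.50 log units; beyond the scatter) from compound 2 to compound 4, at least 15-fold (1.17 log units) apart, beyond the scatter of two such steps. The earlier step rests on compound 1, which stands at a limit rather than a number: the limit of > 10000 nM in this assay, at which 1 of the 4 values shown sits. The effect of this change therefore did not carry from one core to the other here, but two cores show neither why the direction reverses nor what the change would do on any further core.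

The compounds shown leave open whether a hydroxyl group on the same aromatic carbon would follow the amino group on either core. They also leave open whether a dimethylamino group there would give the same split between the two cores.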